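The source may hold more compounds than are shown below. What is called first, only, known or untested is meant among the compounds shown, and "the series" means these compounds.

Compound 1 `Oc1ccccc1/C=N/c1nnc[nH]1` reaches only the limit > 30000 nM in a functional assay on PC-3 cells (Homo sapiens) for cytotoxicity; on this read-out lower numbers stand for stronger inhibition and higher numbers for weaker inhibition.
Compound 2 `COc1cccc(/C=N/c2nnc[nH]2)c1O` likewise reaches only the limit > 30000 nM in this assay.
Compound 3 `COc1ccc(/C=N/n2cnnc2)cc1` also reaches only the limit > 30000 nM in this assay.

Each of these values is a limit of the assay rather than a number: the limit of > 30000 nM in this assay, at which 3 of the 3 values shown sit. Compound 1 and compound 2 differ by methoxy in place of hydrogen on an aromatic carbon, and the step that the two limits leave unreadable from compound 1 to compound 2. The difference between the core of compound 1 and the core of compound 3 is not broken down here. Compound 4 `COc1ccc(/C=N/n2cnnc2)cc1OC` has not been measured; it differs from compound 3 by methoxy in place of hydrogen on an aromatic carbon, the same kind of change as from compound 1 to compound 2, though there the place is ortho to a hydroxy group and here ortho to a methoxy group. Because every value sits at the limit of > 30000 nM in this assay, at which 3 of the 3 values shown sit, compound 4 is expected to stay at the limit as well, a step of a number no higher from compound 3 to compound 4 (the limit leaves the size open) in this assay beside the earlier one. The estimate for compound 4 is 30000 nM, with a range from 10000 nM to 100000 nM.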

Compound 4, half-maximal inhibitory concentration: > 30000 nM
Compound 4 gave a limit, no number; the forecaster's own chance of this, stated with the estimate: 85%; the middle value lies on the limit itself.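

Compound 3 and compound 4 each give only a limit of the assay, not a number, so the step between them cannot be read. How strongly any of the four compounds acts stays open in this assay: the limit of > 30000 nM in this assay, at which 4 of the 4 values shown sit.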